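The source may hold more compounds than are shown below. What is called first, only, known or untested is meant among the compounds shown, and "the series" means these compounds.

Compound 3 `Cc1ccc(C2=NN(c3nc(-c4ccc(F)cc4)cs3)C(c3ccc(F)cc3)C2)s1` is the only one of the three measured compounds that gives a number in a functional assay on A549 cells (Homo sapiens) for antiproliferative activity, read by XTT assay, with a stated time of 24 h (on this read-out higher numbers stand for weaker inhibition and lower numbers for stronger inhibition), where compound 3 gives 125 ug/mL. Compound 1 `Cc1ccc(C2=NN(c3nc(-c4ccc(Cl)cc4)cs3)C(c3ccc(F)cc3)C2)s1` reaches only a limit, giving > 500 ug/mL in this assay. Compound 2 `Cc1ccc(-c2csc(N3N=C(c4ccc(C)s4)CC3c3ccc(F)cc3)n2)cc1` likewise reaches only a limit, giving > 500 ug/mL. Compound 4 `COc1ccc(-c2csc(N3N=C(c4ccc(C)s4)CC3c3ccc(F)cc3)n2)cc1` differs from compound 3 by methoxy in place of fluoro on an aromatic carbon. The measured steps that bear on this change are an at least 4.0-fold lower number from compound 1 to compound 3 (0.60 log units; beyond the scatter) and an at least 4.0-fold lower number from compound 2 to compound 3 (0.60 log units; beyond the scatter), both putting fluoro in place of chloro or methyl on an aromatic carbon. Methoxy in place of fluoro runs opposite to those steps, so a higher number is expected, possibly back at the limit (the limit of > 500 ug/mL in this assay, at which 2 of the 3 values shown sit). Compound 4 is therefore expected to give 400 ug/mL, with a range from 150 ug/mL to 1000 ug/mL, an expected step of a 3.2-fold higher number from compound 3 to compound 4 (0.51 log units; beyond the scatter).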

Compound 4, half-maximal inhibitory concentration: 184 ug/mL
The estimate for compound 4 lay 2.2-fold (0.34 log units) above the measured number; the range from low to high includes it.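

In this assay, 4-methoxyphenyl in place of 4-fluorophenyl gives a 1.5-fold higher number from compound 3 to compound 4 (0.17 log units; within the scatter), so the two groups are not told apart at this position. Methoxy, like fluoro, therefore gives a readable number here, with an at least 2.7-fold lower number from compound 2 to compound 4 (0.43 log units; beyond the scatter) and an at least 2.7-fold lower number from compound 1 to compound 4 (0.43 log units; beyond the scatter). Compound 1 and compound 2 stay at a limit of the assay, not a number: the limit of > 500 ug/mL in this assay, at which 2 of the 4 values shown sit.

The compounds shown leave open whether an amine, a hydroxyl or a carboxylic acid at this position would also give a readable number. They also leave open whether a longer chain, such as ethoxy, would do so.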